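A few compounds are considered here, and "the series" means these few. Any claim that something is new, unique, unknown or untested is made for them only; others in the source may bear on it.

Measured so far:
- compound 1 `CCOC(=O)c1cc(-c2ccc(Oc3ccccc3)cc2)nn1Cc1cccc(NC(=O)CCl)c1`: 400 nM
- compound 2 `C=CC(=O)Nc1ccc(Cn2nc(-c3ccc(Oc4ccccc4)cc3)cc2C(=O)OCC)cc1`: 10900 nM
- compound 3 `C=CC(=O)Nc1cccc(Cn2nc(-c3ccc(Oc4ccccc4)cc3)cc2C(=O)OCC)c1`: 7600 nM

In a functional assay on JeKo-1 cells (Homo sapiens) for inhibition, read by luminescence and CellTiter-Glo, with a stated time of 72 h (a higher number here means a weaker inhibitor, a lower number a stronger inhibitor), compound 1 stands lowest of the three; from it the steps run a 19-fold higher number from compound 1 to compound 3 (1.28 log units; beyond the scatter) and a 27-fold higher number from compound 1 to compound 2 (1.44 log units; beyond the scatter), while between the acrylamides the step is a 1.4-fold lower number from compound 2 to compound 3 (0.16 log units; within the scatter), so compound 1 is the strongest inhibitor shown.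

Compound 4 `O=C(CCl)Nc1cccc(Cn2nc(-c3ccc(Oc4ccccc4)cc3)cc2CO)c1` keeps the chloroacetamide of compound 1 and alters the core: hydroxymethyl in place of ethoxycarbonyl on an aromatic carbon. Within the data shown here, none of the measured steps touches this position; all three concern the acylated aniline, so the ester-to-alcohol change has no measured precedent here. The step of a 2.0-fold higher number from compound 1 to compound 4 (0.30 log units; within the scatter) is therefore an expectation without direct support, placed near no change and allowing for some loss. Compound 4 is estimated at 800 nM in this assay, within 200 nM to 4000 nM.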

Compound 4, half-maximal inhibitory concentration: 400 nM
Beside the measured number, compound 4's estimate is 2.0-fold (0.30 log units) above it, within the range that was stated.
By their numbers in this assay, from the lowest: compounds 1 and 4 (each within the scatter of the next); then compounds 3 and 2 (each within the scatter of the next).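

In this assay, hydroxymethyl in place of ethoxycarbonyl gives no change at the digits printed from compound 1 to compound 4 (within the scatter). With the chloroacetamide held fixed, the ethoxycarbonyl is therefore not required to keep this level of inhibition, and this aromatic carbon accepts a smaller group that carries a hydrogen-bond donor. No evidence on hand accounts for this result.

Still open, from the compounds shown here alone, is whether a carboxylic acid, an aminomethyl group or a hydroxyethyl chain at this carbon would hold the number. Also open, going by these compounds, is whether hydroxymethyl would give a similar result alongside the acrylamide of compound 3.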